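The source may hold more compounds than are shown below. What is called first, only, known or untested is meant among the compounds shown, and "the series" means these compounds.

In a functional assay on A549 cells (Homo sapiens) for antiproliferative activity, read by MTT assay, with a stated time of 24 h (on this read-out higher numbers stand for weaker inhibition and lower numbers for stronger inhibition), three compounds have been measured. Compound 1 `O=C(NNc1ccccc1F)c1cccc(NS(=O)(=O)c2cnc(O)nc2O)c1` gives 11100 nM. Compound 2 `O=C(NNc1ccc(F)cc1)c1cccc(NS(=O)(=O)c2cnc(O)nc2O)c1` returns only a limit of the assay, > 20000 nM. Compound 3 `O=C(NNc1ccccc1F)c1ccccc1NS(=O)(=O)c1cnc(O)nc1O` gives 9610 nM.

Compound 1 and compound 2 share one core and differ in a single place: 4-fluorophenyl in place of 2-fluorophenyl on an amine nitrogen. That change produced an at least 1.8-fold higher number from compound 1 to compound 2 (0.25 log units; that floor lies within the scatter). The step is only a floor because compound 2 sits at the limit of > 20000 nM in this assay, at which 1 of the 3 values shown sits, so the true weakening may be larger than stated.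

Compound 3 is built on a different core; the difference between the two cores is not broken down here. The values of compound 1 and compound 3 lie within the usual scatter of each other.

Compound 4 `O=C(NNc1ccc(F)cc1)c1ccccc1NS(=O)(=O)c1cnc(O)nc1O` stands to compound 3 exactly as compound 2 stands to compound 1: 4-fluorophenyl in place of 2-fluorophenyl on an amine nitrogen, with the same surroundings at the place of change, so this is the same change. The expected step from compound 3 to compound 4 is a 2.1-fold higher number from compound 3 to compound 4 (0.32 log units; beyond the scatter), resting on the measured step of an at least 1.8-fold higher number from compound 1 to compound 2 (0.25 log units; that floor lies within the scatter). Compound 4 is therefore estimated at about 20000 nM, most likely between 10000 nM and 50000 nM, and it may well come back only as a limit.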

Compound 4, half-maximal inhibitory concentration: > 20000 nM
Compound 4 was reported as a limit; the forecaster's own chance of this, stated with the estimate: 50%; the middle value sits exactly at the limit.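

In this assay, putting 4-fluorophenyl in place of 2-fluorophenyl on the core of compound 3 gives an at least 2.0-fold higher number from compound 3 to compound 4 (0.31 log units; beyond the scatter), so the number rises on this core as it did on the core of compound 1, although the floor on that first core lies within the scatter. Compound 4 gives > 20000 nM, which is a limit of the assay and not a number. Both steps are therefore only floors, so the two pairs point the same way when the change is carried from one core to the other, but they do not show that its size carries over: the same change on two cores in this assay, an at least 1.8-fold higher number (0.25 log units; that floor lies within the scatter) from compound 1 to compound 2 and an at least 2.0-fold higher number (0.31 log units; beyond the scatter) from compound 3 to compound 4; the limit leaves it open whether they differ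

The true values of the two 4-fluorophenyl compounds stay unknown, and so does the real size of each step: the limit of > 20000 nM in this assay, at which 2 of the 4 values shown sit. The compounds shown also leave open how these two cores respond to a plain phenyl group without fluorine, or to a chlorophenyl group, on the same amine nitrogen.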